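From 3-methylbenzyl to isopropyl on the sulfur of compound 3

A few compounds are considered here, and "the series" means these few. Any claim that something is new, unique, unknown or untested is made for them only; others in the source may bear on it.

Of the compounds shown here, three sharing one core have been measured so far. Compound 3 `Cc1cccc(CSc2n[nH]c(-n3[se]c4ccccc4c3=O)n2)c1` carries a 3-methylbenzyl group on the sulfur. In an ADME assay on L929 cells (Mus musculus) for antiproliferative activity, read by CCK-8 assay, with a stated time of 48 h (a lower number here means a stronger inhibitor, a higher number a weaker inhibitor), compound 3 gives only the limit > 50000 nM, which is the edge of the assay and not a number. Compound 2 `Cc1ccc(CSc2n[nH]c(-n3[se]c4ccccc4c3=O)n2)cc1` likewise gives only the limit > 50000 nM in this assay. Compound 1 `CCCCSc1n[nH]c(-n2[se]c3ccccc3c2=O)n1` gives 30400 nM in this assay. Compound 3 therefore stands at the limit of > 50000 nM in this assay, at which 2 of the 3 values shown sit.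

Compound 4 `CC(C)Sc1n[nH]c(-n2[se]c3ccccc3c2=O)n1` differs from compound 3 in one place: isopropyl in place of 3-methylbenzyl on a sulfur. The measured steps that bear on this change run in the opposite direction, from a propyl chain to a benzyl group: an at least 1.6-fold higher number from compound 1 to compound 2 (0.21 log units; that floor lies within the scatter) and an at least 1.6-fold higher number from compound 1 to compound 3 (0.21 log units; that floor lies within the scatter). Both are floors only, and both lie within the scatter. The step that the two limits leave unreadable from compound 2 to compound 3 cannot be read. Returning to a short chain, as compound 1 carries, the expectation for compound 4 is a number close to that of compound 1, meaning at most a modest move toward a lower number in this assay, possibly none beyond the scatter. Compound 4 is estimated at 35000 nM, within a range from 15000 nM to 80000 nM. This amounts to an expected at least 1.4-fold lower number from compound 3 to compound 4 (0.15 log units; that floor lies within the scatter).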

Compound 4, half-maximal inhibitory concentration: 37100 nM
Estimate against measurement, compound 4: 1.1-fold (0.03 log units) below; low and high end bracket the measured number.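

In this assay, putting isopropyl in place of a methylbenzyl group on the sulfur now yields a measured number at this position, but the floors on this change stay small: an at least 1.3-fold lower number from compound 3 to compound 4 (0.12 log units; that floor lies within the scatter), and an at least 1.3-fold lower number from compound 2 to compound 4 (0.12 log units; that floor lies within the scatter). Neither floor shows a real gain, though each now rests on a short branched chain as well as on the straight chain of compound 1. Within the data shown here, the two short chains cannot be told apart, with a 1.2-fold higher number from compound 1 to compound 4 (0.09 log units; within the scatter), so branching at this position makes no readable difference, and the only two compounds here that give a number rather than a limit are the two with short chains, compound 1 and compound 4.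

From the compounds shown here alone, whether a longer chain, or a chain ending in an amine or a carboxylic acid, on the sulfur would move the number beyond the scatter stays open. The true gap between short chains and benzyl groups also stays open, and the step between the two benzyl compounds cannot be read, since compound 2 and compound 3 give only limits of the assay, not numbers: the limit of > 50000 nM in this assay, at which 2 of the 4 values shown sit.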